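The compounds below may be only part of what the source reports. "The series", "measured", "known", "first", "only" and "open" are said of these compounds alone.

Three compounds were measured in an ADME assay (MDM cells, Homo sapiens) for cytotoxicity, read by resazurin assay, with a stated time of 3 days; on this read-out higher numbers stand for weaker inhibition and lower numbers for stronger inhibition:

Compound 1 `O=C(CCl)Nn1c(S)nnc1COc1ccccc1C1=NOC(c2ccc(Cl)cc2Cl)C1` gives 3.2 ug/mL.
Compound 2 `CCSc1nnc(COc2ccccc2C2=NOC(c3ccc(Cl)cc3Cl)C2)n1NC(=O)c1ccccc1` gives 1.8 ug/mL.
Compound 3 `CCSc1nnc(COc2ccccc2C2=NOC(c3ccc(Cl)cc3Cl)C2)n1NC(C)=O` gives 9.7 ug/mL.

Compound 3 gives the highest of the three numbers, so it is the weakest inhibitor here; compound 1 comes nearest and compound 2 lies furthest away. Going by the values given here, the one measured step, a 5.4-fold higher number from compound 2 to compound 3 (0.73 log units; beyond the scatter), concerns the group on the carbonyl carbon and not the chain on the sulfur.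

Compound 4 `CCCCSc1nnc(COc2ccccc2C2=NOC(c3ccc(Cl)cc3Cl)C2)n1NC(C)=O` differs from compound 3 as follows: ethyl in place of hydrogen on a saturated chain carbon, two bonds along the chain from a sulfur. Among the compounds with values here, no measured step touches that chain, so nothing seen so far suggests a change beyond the scatter. Compound 4 is therefore expected to stay close to compound 3, with an estimated step of a 1.3-fold lower number from compound 3 to compound 4 (0.11 log units; within the scatter). The estimated value of compound 4 is 7.5 ug/mL, in a range from 3 ug/mL to 19 ug/mL.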

Compound 4, half-maximal inhibitory concentration: 2.6 ug/mL
Compound 4: middle estimate off by 2.9-fold (0.46 log units), on the high side; measured number below the stated range.
By their numbers in this assay, from the lowest: compounds 2, 4 and 1 (each within the scatter of the next); then compound 3.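

Going by these compounds alone, changing ethylsulfanyl to butylsulfanyl produces a 3.7-fold lower number from compound 3 to compound 4 (0.57 log units; beyond the scatter) in this assay and so shows that the chain on the sulfur, which no earlier step touched, also moves this number. Adding only an ethyl in place of a hydrogen on that chain is enough for a step beyond the usual scatter. Nothing available here explains this step.

As far as these compounds go, whether a longer chain on the sulfur would lower the number further remains open. So does the effect of an amine or a carboxylic acid at the end of that chain.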